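Series notes: bromo for methoxy, compound 2 to compound 4

The source may hold more compounds than are shown below. What is called first, only, known or untested is meant among the compounds shown, and "the series" means these compounds.

Measured so far:
compound 1 `Cn1ccc2ccc3c(c4c(c5c6cccc7c6n(c35)CC(CO)C7)C(=O)NC4=O)c21`: 210 nM
compound 2 `COc1ccc2c(c1)[nH]c1c2c2c(c3c4cccc5c4n(c13)CC(CO)C5)C(=O)NC2=O`: 1960 nM
compound 3 `O=C1NC(=O)c2c1c1c3ccccc3ccc1c1c2c2cccc3c2n1CCC3CO`: 1720 nM

In a functional assay on NCI-H460 cells (Homo sapiens) for antiproliferative activity (on this read-out higher numbers stand for weaker inhibition and lower numbers for stronger inhibition), compound 2 stands at the highest of the three numbers, which means the weakest inhibition among them. Its nearest neighbour is compound 3, whose number is within the scatter of that of compound 2, so no order can be read between these two. Compound 1 sits far lower, beyond the scatter, and is the only one of the three that separates clearly from compound 2.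

Compound 4 `O=C1NC(=O)c2c1c1c3ccc(Br)cc3[nH]c1c1c2c2cccc3c2n1CC(CO)C3` is not yet measured. It differs from compound 2 in one place: bromo in place of methoxy on an aromatic carbon. Among the compounds with values here, no pair of measured compounds isolates this change, so nothing so far tells the size or direction of the step. Given the lack of a comparable step, a small change is expected, leaning toward a lower number, but possibly none beyond the scatter; the step from compound 2 to compound 4 is estimated at a 1.6-fold lower number from compound 2 to compound 4 (0.21 log units; within the scatter). For compound 4 the expected value in this assay is 1200 nM, with a range of 300 nM to 4500 nM.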

Compound 4, half-maximal inhibitory concentration: 360 nM
Compound 4: middle estimate off by 3.3-fold (0.52 log units), on the high side, within the range that was stated.
By their numbers in this assay, from the lowest: compounds 1 and 4 (each within the scatter of the next); then compounds 3 and 2 (each within the scatter of the next).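

In this assay, this position gives the series its first step between compounds that differ in one place: bromo in place of methoxy gives a 5.4-fold lower number from compound 2 to compound 4 (0.74 log units; beyond the scatter) and lies beyond the scatter, toward stronger inhibition. The earlier compounds shown here contained no such pair, so they could not show that the read-out responds to the group on this aromatic carbon, which sits on a six-membered aromatic ring of carbon only, part of the fused system. Nothing available explains the step, so it stands as an observation on this one pair and this one shared core.

The two groups alone do not show whether bromo gives the better read-out among substituents here or methoxy the poorer one, since no compound shown carries plain hydrogen at this carbon, and chloro, nitrile, an amine or a carboxylic acid are also absent from the set. On these data alone, whether the same exchange would give a step of similar size or direction on the cores of compound 1 or compound 3 also remains open.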